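A few compounds are considered here, and "the series" means these few. Any claim that something is new, unique, unknown or untested is made for them only; others in the source may bear on it.

Within the data shown here, compound 1 `CCN(CC)S(=O)(=O)c1ccc(S(=O)(=O)N2CCC[C@@H](C(=O)NC3COC3)C2)cc1` is the weakest of the three compounds measured so far. In a functional assay on BXPC-3 cells (Homo sapiens) for inhibition, read by MTT assay, with a stated time of 7 days (a lower number here means a stronger inhibitor, a higher number a weaker inhibitor), compound 1 gives 13800 nM, the highest number of the set. Its nearest neighbour is compound 3 `CCN(CC)S(=O)(=O)c1ccc(S(=O)(=O)N2CCC[C@@H](C(=O)N3CCC(C(F)(F)F)CC3)C2)cc1`, which in this assay gives 370 nM, and the gap to compound 2 `CC(C)S(=O)(=O)c1ccc(S(=O)(=O)N2CCC[C@@H](C(=O)N3CCC(F)(F)CC3)C2)cc1`, which in this assay gives 50 nM, is wider still.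

Compound 4 `CCN(CC)S(=O)(=O)c1ccc(S(=O)(=O)N2CCC[C@@H](C(=O)N3CCC(F)(F)CC3)C2)cc1` shares the core of compound 1 and differs from it in one place: 4,4-difluoropiperidin-1-yl in place of (oxetan-3-yl)amino on a carbonyl carbon. Among the measured compounds shown here, one measured step bears directly on this change. Replacing the same (oxetan-3-yl)amino group with 4-(trifluoromethyl)piperidin-1-yl gave a 37-fold lower number from compound 1 to compound 3 (1.57 log units; beyond the scatter), a large improvement well beyond the scatter. For the measured compounds named here, compound 2 carries the same 4,4-difluoropiperidin-1-yl group as compound 4 but differs from it elsewhere in the molecule, so its value shows only that this ring can sit in a strongly inhibiting compound; no single step links it to compound 4. On the strength of the step to compound 3, the replacement in compound 4 is expected to lower the number substantially, by a 46-fold lower number from compound 1 to compound 4 (1.66 log units; beyond the scatter). Compound 4 is therefore estimated at 300 nM, with a likely range from 90 nM to 1000 nM.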

Compound 4, half-maximal inhibitory concentration: 120 nM
For compound 4 the middle estimate is 2.5-fold (0.40 log units) above the measured one, and the stated range covers the measured number.
By their numbers in this assay, from the lowest: compound 2; then compound 4; then compound 3; then compound 1.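

In this assay, the move to 4,4-difluoropiperidin-1-yl on the carbonyl carbon gives a 120-fold lower number from compound 1 to compound 4 (2.06 log units; beyond the scatter), so a second six-membered ring, not only the 4-(trifluoromethyl)piperidin-1-yl ring, far outperforms (oxetan-3-yl)amino on the core of compound 1. The two rings are not interchangeable, as swapping 4-(trifluoromethyl)piperidin-1-yl for 4,4-difluoropiperidin-1-yl gives a 3.1-fold lower number from compound 3 to compound 4 (0.49 log units; beyond the scatter), which shows that what the piperidine ring carries also affects the number, though less than leaving the oxetane amide does. The other end of the molecule matters too: with the 4,4-difluoropiperidin-1-yl ring held constant, diethylamino in place of isopropyl on the sulfonyl sulfur gives a 2.4-fold higher number from compound 2 to compound 4 (0.38 log units; beyond the scatter), a step of modest size.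

The oxetane amide differs from both piperidines in ring size and in having the amide hydrogen, so these compounds cannot separate those two features, and a plain unsubstituted piperidine, a morpholine or a simple diethylamide on the carbonyl would test how much fluorine contributes. No measurement offered here accounts for the size of any of these steps.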